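Compound 4: methyl to 4-bromobenzyl

The source may report more compounds than this note shows. Statements on the series, on what has been measured and on what is new or still open speak of the compounds shown alone.

Compound 1 `CN1C(=O)C(O)(Cc2nnn[nH]2)c2ccccc21`: 45500 nM
Compound 2 `CN1C(=O)C(O)(Cc2nnn[nH]2)c2cc(F)ccc21`: > 100000 nM (a limit)
Compound 3 `CN1C(=O)C(O)(Cc2nnn[nH]2)c2cc(Cl)ccc21`: > 100000 nM (a limit)

All three compounds were tested in a functional assay on PA-1 cells (Homo sapiens) for antiproliferative activity, read by MTT assay, with a stated time of 48 h; on this read-out lower numbers stand for stronger inhibition and higher numbers for weaker inhibition. Compound 3 stands at > 100000 nM, which is a limit and not a number. The change to compound 4 `O=C1N(Cc2ccc(Br)cc2)c2ccc(Cl)cc2C1(O)Cc1nnn[nH]1` is 4-bromophenyl in place of hydrogen on a saturated chain carbon bound to an amide-type nitrogen in a ring. Cut one bond further out, it reads methyl to 4-bromobenzyl.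

The measured steps bear on this only loosely. They are an at least 2.1-fold higher number from compound 1 to compound 2 (0.34 log units; beyond the scatter) and an at least 2.1-fold higher number from compound 1 to compound 3 (0.34 log units; beyond the scatter). Within the data shown here, both are changes on an aromatic carbon, and no measured step touches the place that changes here, so they give no size for it. Among the measured compounds shown here, the only actual number so far is that of compound 1, at 45500 nM. Any readable value for compound 4 would lie under the limit of compound 3, so a modest move towards a lower number is expected, though the limit may well hold. The expected change is an at least 3.3-fold lower number from compound 3 to compound 4 (0.52 log units; beyond the scatter). Compound 4 is expected at 30000 nM, with an estimated range from 6000 nM to 100000 nM.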

Compound 4, half-maximal inhibitory concentration: 35800 nM
Compound 4: the middle estimate sits 1.2-fold (0.08 log units) below what was measured; measured number inside the range.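

In this assay, the change from methyl to 4-bromobenzyl gives an at least 2.7-fold lower number from compound 3 to compound 4 (0.44 log units; beyond the scatter). Among these compounds, this is the first measured change on the saturated chain carbon bound to an amide-type nitrogen in a ring, and it moves towards a lower number, whereas the two readable earlier steps, both on an aromatic carbon, moved towards a higher one. Compound 3 has only a limit here, so the step has a minimum size but no exact one: the limit of > 100000 nM in this assay, at which 2 of the 4 values shown sit.

The compounds shown hold only methyl and 4-bromobenzyl at this place, so they do not tell whether the bromine matters or whether a plain benzyl or a longer alkyl chain such as butyl would serve equally. On these data alone, it also stays open whether the same change would give a similar step on the core of compound 1, which has hydrogen in place of the chloro.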